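Methyl on the Amine Nitrogen of a Fluoroindole Inhibitor

The source may hold more compounds than are shown below. What is called first, only, known or untested is meant among the compounds shown, and "the series" means these compounds.

Compound 1 `CCN(CC)Cc1c[nH]c2ccc(F)cc12` gives 200 nM in an assay on urine for inhibition of Myeloperoxidase (Homo sapiens); on this read-out lower numbers stand for stronger inhibition and higher numbers for weaker inhibition. Compound 2 `NCCCc1c[nH]c2ccc(F)cc12` gives 50 nM in this assay.

Going by the values given here, compound 2 holds the lowest of the two numbers measured so far; the only other number, that of compound 1, sits a 4.0-fold lower number from compound 1 to compound 2 (0.60 log units; beyond the scatter) away in the step from compound 1 to compound 2. Compound 3 `CNCCCc1c[nH]c2ccc(F)cc12` has not yet been measured. It differs from compound 2 by methyl in place of hydrogen on an amine nitrogen. Among the compounds with values here, only one measured step bears on this change: the step from compound 1 to compound 2, in which diethylamino was replaced by 2-aminoethyl and the number fell, a 4.0-fold lower number from compound 1 to compound 2 (0.60 log units; beyond the scatter). Adding one methyl to the amine nitrogen of compound 2 moves a small part of the way back toward the substitution pattern of compound 1, so a step of a 1.6-fold higher number from compound 2 to compound 3 (0.20 log units; within the scatter) is expected for compound 3, modest and within or just beyond the scatter. Compound 3 is therefore estimated at 80 nM, with a range from 30 nM to 250 nM.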

Compound 3, half-maximal inhibitory concentration: 200 nM
The estimate for compound 3 lay 2.5-fold (0.40 log units) below the measured number, within the range that was stated.
By their numbers in this assay, from the lowest: compound 2; then compounds 1 and 3 (each within the scatter of the next).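

In this assay a single methyl on the amine nitrogen is enough to give a 4.0-fold higher number from compound 2 to compound 3 (0.60 log units; beyond the scatter), so this nitrogen responds to the smallest substitution tried on it. The step between the two substituted amines reads no change at the digits printed from compound 1 to compound 3 (within the scatter), which leaves compound 2, with its unsubstituted amine, as the only one of the three standing apart from the others beyond the scatter. Nothing measured here accounts for this result.

From the compounds shown here alone, it remains open whether a 2-(dimethylamino)ethyl group would read like compound 3 or move further, and whether an amide on this nitrogen would behave like the methyl. Also open, going by these compounds, is how a longer chain between the unsubstituted amine and the shared core would read.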